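Swapping One Side Group on a Shared Core

The source may hold more compounds than are shown below. What is called first, only, known or untested is meant among the compounds shown, and "the series" means these compounds.

For the measured compounds named here, in a toxicity assay on HEK-293T cells (Homo sapiens) for cytotoxicity, read by MTT assay, with a stated time of 72 h (a lower number here means a stronger inhibitor, a higher number a weaker inhibitor), compound 1 (`O=C1c2c[n+]([O-])c3ccccc3c2C(=O)c2c1c1ccccc1n2Cc1cn([C@H]2O[C@H](CO)[C@@H](O)[C@H]2O)nn1`) gives 1370 nM and compound 2 (`CC1(C)OCC(Cn2cc(Cn3c4c(c5ccccc53)C(=O)c3c[n+]([O-])c5ccccc5c3C4=O)nn2)O1`) gives 5510 nM, the higher of the only two numbers known so far. Compound 3 (`O=C1c2c[n+]([O-])c3ccccc3c2C(=O)c2c1c1ccccc1n2Cc1cn(CC(O)CO)nn1`) carries 1,2-dihydroxyethyl in place of the 2,2-dimethyl-1,3-dioxolan-4-yl of compound 2, on a saturated chain carbon bound to an aromatic nitrogen (1,2-dihydroxyethyl in place of 2,2-dimethyl-1,3-dioxolan-4-yl on a saturated chain carbon bound to an aromatic nitrogen). Going by the values given here, one measured step bears on this: a 4.0-fold higher number from compound 1 to compound 2 (0.60 log units; beyond the scatter), a modest change beyond the scatter, which brought in the (2,2-dimethyl-1,3-dioxolan-4-yl)methyl group in place of 3,4-dihydroxy-5-(hydroxymethyl)oxolan-2-yl. Compound 3 has dihydroxy groups there, as compound 1 at 1370 nM does, though the two groups are not the same, so a partial return toward that number is expected. The expected step is a 2.1-fold lower number from compound 2 to compound 3 (0.33 log units; beyond the scatter), towards a lower number in this assay. For compound 3 the estimate is 2600 nM, with an expected range of 1100 nM to 6000 nM.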

Compound 3, half-maximal inhibitory concentration: 760 nM
For compound 3 the middle estimate is 3.4-fold (0.53 log units) above the measured one; measured number below the stated range.
By their numbers in this assay, from the lowest: compounds 3 and 1 (each within the scatter of the next); then compound 2.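

In this assay, the open 1,2-dihydroxyethyl group gives a 7.3-fold lower number from compound 2 to compound 3 (0.86 log units; beyond the scatter) when it replaces the closed 2,2-dimethyl-1,3-dioxolan-4-yl ring on a saturated chain carbon bound to an aromatic nitrogen. The other comparison adds something new: a 1.8-fold lower number from compound 1 to compound 3 (0.26 log units; within the scatter) shows that the simple 2,3-dihydroxypropyl chain and the larger ring-bearing 3,4-dihydroxy-5-(hydroxymethyl)oxolan-2-yl group cannot be told apart here, so a ring is not needed at this place to reach that level. Among these three compounds, the two with free hydroxyl groups both have clearly lower numbers than compound 2, and none goes against this pattern. Going by these compounds, whether the free hydroxyl groups matter, or only the loss of the closed ring with its two methyl groups, remains open, and an amine or a methoxy-capped chain at the same place could help separate the two. No measurement shown gives a reason for the shift.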